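From pyrrolidin-1-yl to dimethylamino at the assay limit

The compounds below may be only part of what the source reports. "The series", "measured", "known", "first", "only" and "open" are said of these compounds alone.

Compound 1 `CCN(CC)CC(=O)Nc1ccc(Nc2cc(Cl)nc(-c3ccc(OC)cc3)n2)cc1` gives 15000 nM
Compound 2 `COc1ccc(-c2nc(Cl)cc(Nc3ccc(NC(=O)CN4CCCC4)cc3)n2)cc1` gives 4820 nM
Compound 3 `COc1ccc(-c2nc(Cl)c(-c3ccccc3)c(Nc3ccc(NC(=O)CN4CCCC4)cc3)n2)cc1` gives > 40000 nM (a limit)

These values come from a functional assay on HUVEC cells (Homo sapiens) for antiproliferative activity, read by MTT assay, with a stated time of 48 h (on this read-out higher numbers stand for weaker inhibition and lower numbers for stronger inhibition), as the read-out. Compound 3 has only a limit (> 40000 nM) and no exact number. Compound 4 `COc1ccc(-c2nc(Cl)c(-c3ccccc3)c(Nc3ccc(NC(=O)CN(C)C)cc3)n2)cc1` alters one group (dimethylamino in place of pyrrolidin-1-yl on a saturated chain carbon bound to a carbonyl carbon), with dimethylamino in place of pyrrolidin-1-yl on a saturated chain carbon bound to a carbonyl carbon.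

The closest measured change at this place is a 3.1-fold lower number from compound 1 to compound 2 (0.49 log units; beyond the scatter) and it points to a modest effect at most. Phenyl stays in the new compound, and adding it brought an at least 8.2-fold higher number from compound 2 to compound 3 (0.91 log units; beyond the scatter) as the larger measured step. Little movement is therefore expected, and the expected step is a number no higher from compound 3 to compound 4 (the limit leaves the size open) in this assay with no clear direction. For compound 4 the estimated value is 40000 nM with an expected range (15000 nM to 80000 nM).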

Compound 4, half-maximal inhibitory concentration: 10400 nM
The estimate for compound 4 lay 3.8-fold (0.59 log units) above the measured number; the measured number lies below the stated range.
By their numbers in this assay, from the lowest: compound 2; then compounds 4 and 1 (each within the scatter of the next). At a limit, above all of these: compound 3.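

In this assay, the group on the saturated chain carbon bound to a carbonyl carbon still counts when phenyl is present: dimethylamino in place of pyrrolidin-1-yl gives an at least 3.8-fold lower number from compound 3 to compound 4 (0.58 log units; beyond the scatter). Going by these compounds alone, the earlier step at this place came from compounds without phenyl, so this change adds a first reading with it. The true size of the step stays open because compound 3 has only a limit: the limit of > 40000 nM in this assay, at which 1 of the 4 values shown sits.

On these data alone, whether dimethylamino would give a similar step without phenyl remains open. So does how piperidin-1-yl, morpholin-4-yl or a longer chain would read at this place.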